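The compounds below may be only part of what the source reports. "The series", "measured", "known", "first", "only" and "open" are said of these compounds alone.

Working notes on the series.

Compound 1 `NCC(=O)NCc1nnc(-c2ccc(F)cc2)o1` is the reference point: in an assay for inhibition of histone deacetylase 8 (Homo sapiens), read by fluorescence, with a stated time of 15 min (a higher number here means a weaker inhibitor, a lower number a stronger inhibitor), compound 1 gives 135 nM. Compound 2 `C[C@@H](N)C(=O)NCc1nnc(-c2ccc(F)cc2)o1` carries the change methyl in place of hydrogen on a saturated chain carbon bound to an amine nitrogen and a carbonyl carbon and in this assay compound 2 gives 116 nM, a step of a 1.2-fold lower number from compound 1 to compound 2 (0.07 log units; within the scatter). Compound 3 `NCC(=O)NCc1nnc(-c2ccc([N+](=O)[O-])cc2)o1` differs from compound 1 in its core by nitro in place of fluoro on an aromatic carbon; in this assay compound 3 gives 134 nM, a step of a 1.0-fold lower number from compound 1 to compound 3 (0.00 log units; within the scatter). All three measured values lie within the scatter of one another, so no ordering among them is claimed.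

Compound 4 `C[C@@H](N)C(=O)NCc1nnc(-c2ccc([N+](=O)[O-])cc2)o1` has not yet been measured in this assay. It differs from compound 3 by methyl in place of hydrogen on a saturated chain carbon bound to an amine nitrogen and a carbonyl carbon, which is the same change already made from compound 1 to compound 2, at the same place. Going by the values given here, with the step of a 1.2-fold lower number from compound 1 to compound 2 (0.07 log units; within the scatter) as the only precedent, the step of a 1.2-fold lower number from compound 3 to compound 4 (0.07 log units; within the scatter) is expected to be of similar size, that is, essentially flat. On that basis compound 4 is estimated at 115 nM in this assay, with a range of 55 nM to 240 nM allowing for the usual scatter.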

Compound 4, half-maximal inhibitory concentration: 127 nM
The estimate for compound 4 lay 1.1-fold (0.04 log units) below the measured number; measured number inside the range.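

In this assay, methyl in place of hydrogen on the saturated chain carbon gives a 1.1-fold lower number from compound 3 to compound 4 (0.02 log units; within the scatter), and this step agrees with the earlier one on the core of compound 1: the same change on two cores in this assay, a 1.2-fold lower number (0.07 log units; within the scatter) from compound 1 to compound 2 and a 1.1-fold lower number (0.02 log units; within the scatter) from compound 3 to compound 4, 1.1-fold (0.04 log units) apart, within the scatter of two such steps

Nitro in place of fluoro gives a 1.1-fold higher number from compound 2 to compound 4 (0.04 log units; within the scatter), and the two cores again agree for this change: the same change on two cores in this assay, a 1.0-fold lower number (0.00 log units; within the scatter) from compound 1 to compound 3 and a 1.1-fold higher number (0.04 log units; within the scatter) from compound 2 to compound 4, 1.1-fold (0.04 log units) apart, within the scatter of two such steps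

Going by these compounds alone, both changes therefore carry from one core to the other in these four compounds without a difference that can be read, but all of the steps are within the scatter, so this shows only that flat steps stay flat and not that a step of real size would carry across in the same way.

The compounds shown leave open whether any change at these two places moves the number beyond the scatter. A longer chain in place of the methyl, or a carboxylic acid or a nitrile in place of the nitro on the aromatic carbon, would test this and show whether such a step also carries from one core to the other.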